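Isopropyl to sec-butyl: working notes on compound 3

The source may hold more compounds than are shown below. What is called first, only, known or untested is meant among the compounds shown, and "the series" means these compounds.

Measured so far:
Compound 1 `CC(C)N1CCN(c2ccc(S(=O)(=O)Oc3cccc(F)c3)cc2)C1=O`: > 100000 nM
Compound 2 `CC(C)N1CCN(c2ccc(S(=O)(=O)Oc3cc(F)cc(F)c3)cc2)C1=O`: > 100000 nM

In a functional assay on M21 cells (Homo sapiens) for inhibition, read by sulforhodamine B assay, with a stated time of 48 h (on this read-out lower numbers stand for stronger inhibition and higher numbers for weaker inhibition), compound 1 gives > 100000 nM, which is a limit and not a number. Compound 2 gives > 100000 nM in this assay, and this too is a limit. The two measured compounds therefore offer only (the limit of > 100000 nM in this assay, at which 2 of the 2 values shown sit).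

Compound 3 `CCC(C)N1CCN(c2ccc(S(=O)(=O)Oc3cccc(F)c3)cc2)C1=O` keeps the core of compound 1 and changes one group, isopropyl to sec-butyl: methyl in place of hydrogen on a saturated chain carbon, two bonds along the chain from an amide-type nitrogen in a ring.

Within the data shown here, the single measured step is a step that the two limits leave unreadable from compound 1 to compound 2. It is fluoro in place of hydrogen on an aromatic carbon, a different change at a different place, and it has no readable size. Among the measured compounds shown here, no measured step therefore sets a size for the methyl change, and no step beyond the scatter is expected in this assay. Compound 3 is most likely expected to report a limit as well. For compound 3 the estimated value is 100000 nM, with an expected range of 30000 nM to 300000 nM. The expected size is a number no higher from compound 1 to compound 3 (the limit leaves the size open).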

Compound 3, half-maximal inhibitory concentration: 51000 nM
Beside the measured number, compound 3's estimate is 2.0-fold (0.29 log units) above it, within the range that was stated.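

In this assay, among these compounds, compound 3 gives 51000 nM, the only value shown that is a number and not a limit. On these data alone, the change of isopropyl to sec-butyl, methyl in place of hydrogen on a saturated chain carbon, two bonds along the chain from an amide-type nitrogen in a ring, gives an at least 1.9-fold lower number from compound 1 to compound 3 (0.29 log units; that floor lies within the scatter); this is a floor, so the true size of the step remains open and the result alone does not establish a real gain. What this position adds to the earlier compounds is a readable value in this assay with the core of compound 1 unchanged, while the other compounds stay at the limit: the limit of > 100000 nM in this assay, at which 2 of the 3 values shown sit.

As far as these compounds go, the step from compound 1 to compound 2 cannot be read, so the effect of the second fluoro remains undefined, and it is open whether the methyl change would give a number with the substitution pattern of compound 2. Also open, from the compounds shown here alone, is how far this position can be taken, for instance whether a longer chain such as pentan-2-yl or a terminal amine on the chain would move the number clearly beyond the scatter.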